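Shortening the linker in an inactive diester amide

The source may hold more compounds than are shown below. What is called first, only, known or untested is meant among the compounds shown, and "the series" means these compounds.

Compound 1 `Cc1cc2c(cc1C(=O)c1ccc(C(=O)OCCCCOC(=O)c3ccc(C(=O)Nc4ccc5c(c4)C(C)(C)CCC5(C)C)cc3)cc1)C(C)(C)CCC2(C)C` gives 147000 nM in a functional assay on NB-4 cells (Homo sapiens) for inhibition, read by MTT assay, with a stated time of 48 h; on this read-out higher numbers stand for weaker inhibition and lower numbers for stronger inhibition.
Compound 2 `CCCC(CCC)C(=O)OCCCCOC(=O)c1ccc(C(=O)Nc2ccc3c(c2)C(C)(C)CCC3(C)C)cc1` gives > 1000000 nM in this assay; this value is a limit of the assay, not a number.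
Compound 3 `C=C(c1ccc(C(=O)OCCOC(=O)c2ccc(C(=O)Nc3ccc4c(c3)C(C)(C)CCC4(C)C)cc2)cc1)c1cc2c(cc1C)C(C)(C)CCC2(C)C` gives > 1000000 nM in this assay; this too is a limit of the assay.

Only compound 1 yields a number, and that number sits at the weak end of this assay. Compound 2 stands at the limit of > 1000000 nM in this assay, at which 2 of the 3 values shown sit, so its inhibition is not resolved at all. Among the compounds with values here, no pair of measured compounds differs in a single place, so there is no measured step to lean on.

Compound 4 `CCCC(CCC)C(=O)OCCCOC(=O)c1ccc(C(=O)Nc2ccc3c(c2)C(C)(C)CCC3(C)C)cc1` is compound 2 with one change: ((1-propylbutyl)carbonyl)oxy in place of (((1-propylbutyl)carbonyl)oxy)methyl on a saturated chain carbon, three bonds along the chain from an oxygen next to a carbonyl group. The chain between the two ester groups is thus one carbon shorter, while both ends stay as they were. With compound 2 unresolved at the limit of > 1000000 nM in this assay, at which 2 of the 3 values shown sit, the expectation is a step from compound 2 to compound 4 of no size beyond the scatter, that is a number no higher from compound 2 to compound 4 (the limit leaves the size open). Compound 4 is therefore estimated at 1000000 nM, within a range from 300000 nM to 3000000 nM, and most probably the assay will again report only a limit for compound 4.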

Compound 4, half-maximal inhibitory concentration: > 1000000 nM
Compound 4 ended at the assay's limit; the forecaster's own chance of this, stated with the estimate: 80%; the middle value sits exactly at the limit.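

Compound 2 and compound 4 both stop at a limit in this assay rather than at a number, so no step between them can be read: the limit of > 1000000 nM in this assay, at which 3 of the 4 values shown sit.

The compounds shown leave open whether ((1-propylbutyl)carbonyl)oxy in place of (((1-propylbutyl)carbonyl)oxy)methyl changes inhibition at all.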